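The source may hold more compounds than are shown below. What is called first, only, known or untested is meant among the compounds shown, and "the series" means these compounds.

Compound 1, `CCCCCCCCCCOc1cc(OC)c(Br)cc1C(C)=O`, and compound 2, `CCCCCCCCCCCCOc1cc(OC)c(Br)cc1C(C)=O`, share one core; the difference between them is ethyl in place of hydrogen on a saturated chain carbon, ten or more bonds along the chain from an oxygen on an aromatic ring. In a functional assay, with a stated time of 30 min (on this read-out lower numbers stand for stronger inhibition and higher numbers for weaker inhibition), compound 1 gives 35100000 nM, and compound 2 gives 29500000 nM. The step between them, a 1.2-fold lower number from compound 1 to compound 2 (0.08 log units; within the scatter), is small. Compound 3, `CCOc1cc(OC)ccc1C(C)=O`, has a different core; the difference between the two cores is not broken down here. In this assay compound 3 gives 39600000 nM. Compound 4, `CCCCOc1cc(OC)ccc1C(C)=O`, differs from compound 3 by ethyl in place of hydrogen on a saturated chain carbon, two bonds along the chain from an oxygen on an aromatic ring. This is the same kind of change as the earlier one, but the place differs: here the new ethyl sits two bonds along the chain from an oxygen on an aromatic ring, whereas before it sat much further along the chain from an oxygen on an aromatic ring. Compound 4 is expected to give 34000000 nM in this assay because the earlier step was a 1.2-fold lower number from compound 1 to compound 2 (0.08 log units; within the scatter). That means an expected step of a 1.2-fold lower number from compound 3 to compound 4 (0.07 log units; within the scatter).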

Compound 4, half-maximal inhibitory concentration: 43300000 nM
Compound 4: the middle estimate sits 1.3-fold (0.11 log units) below what was measured; measured number inside the range.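

In this assay, the change from ethoxy to butoxy gives a 1.1-fold higher number from compound 3 to compound 4 (0.04 log units; within the scatter). Set beside the earlier step on the other core, it shows no difference that the data can separate: the same change on two cores in this assay, a 1.2-fold lower number (0.08 log units; within the scatter) from compound 1 to compound 2 and a 1.1-fold higher number (0.04 log units; within the scatter) from compound 3 to compound 4, 1.3-fold (0.11 log units) apart, within the scatter of two such steps. So, in these two pairs, adding ethyl to the chain makes little difference on either core, but with both steps this small, the comparison does not show that a larger effect would carry from one core to the other.

On these data alone, it remains open whether an amine or a carboxylic acid in place of the ethyl would give a step beyond the scatter on either core. The effect of the difference between the two cores also remains open, as no pair shown differs in that alone.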